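Replacing Dimethoxyphenyl With Methylsulfonylphenyl: Cytotoxicity Expectation

The source may report more compounds than this note shows. Statements on the series, on what has been measured and on what is new or still open speak of the compounds shown alone.

Compound 3, `COc1cc(OC)cc(-c2ccc(C(=O)N(Cc3cccc(OCCCCCC(=O)O)c3)C(C)C)cc2)c1`, stands in an ADME assay on HEK293 cells (Homo sapiens) for cytotoxicity, read by CellTiter-Glo and resazurin assay, with a stated time of 72 h (on this read-out lower numbers stand for an effect already at smaller amounts and higher numbers for an effect only at larger amounts of compound), only at a limit, > 26000 nM, not at a number. Compound 1, `CC(C)N(Cc1cccc(OCCCCCC(=O)O)c1)C(=O)c1ccc(-c2cccc(Oc3ccccc3)c2)cc1`, likewise reaches only a limit in this assay, > 18700 nM. Compound 2, `CCOc1cccc(-c2ccc(C(=O)N(Cc3cccc(OCCCCCC(=O)O)c3)C(C)C)cc2)c1`, also stops at a limit in this assay, > 20800 nM. Both measured steps, a step that the two limits leave unreadable from compound 1 to compound 2 and a step that the two limits leave unreadable from compound 2 to compound 3, are therefore unreadable in size, as the three limits (the limit of > 18700 nM in this assay, at which 1 of the 3 values shown sits), the limit of > 20800 nM in this assay, at which 1 of the 3 values shown sits, and the limit of > 26000 nM in this assay, at which 1 of the 3 values shown sits, show. Compound 4, `CC(C)N(Cc1cccc(OCCCCCC(=O)O)c1)C(=O)c1ccc(-c2cccc(S(C)(=O)=O)c2)cc1`, differs from compound 3 by 3-(methylsulfonyl)phenyl in place of 3,5-dimethoxyphenyl on an aromatic carbon. Among the measured compounds shown here, no measured step reads clearly, so no shift beyond the usual scatter is expected in this assay; the step that the limit leaves unreadable from compound 3 to compound 4 is an estimate only. Compound 4 is expected to give about 30000 nM, between 12000 nM and 80000 nM, most likely again as a limit.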

Compound 4, half-maximal effective concentration: > 26000 nM
Compound 4: a limit, no number; the forecaster's own chance of this, stated with the estimate: 85%; the middle value is on the limit's open side.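

Compound 4 stops at a limit in this assay, as compound 1, compound 2 and compound 3 do, so none of its steps from those compounds can be read. The concentration giving a half-maximal effect for any of these compounds stays open.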